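The source may report more compounds than this note shows. Statements on the series, on what has been measured and on what is new or still open speak of the compounds shown alone.

Compound 1 `C#CCCCn1c(Cc2cc(OC)c(OC)c(OC)c2)nc2c(N)ncnc21`: 24000 nM
Compound 2 `COc1cc(Cc2nc3c(N)ncnc3n2CC2CCCO2)cc(OC)c1OC`: 91200 nM
Compound 3 `COCCn1c(Cc2cc(OC)c(OC)c(OC)c2)nc2c(N)ncnc21`: 64600 nM

These three share one core and differ only in the group on the saturated chain carbon bound to an aromatic nitrogen. In a functional assay on MCF7 cells (Homo sapiens) for antiproliferative activity (a lower number here means a stronger inhibitor, a higher number a weaker inhibitor), compound 3 gives 64600 nM, the second highest of the three numbers; the nearest step is a 1.4-fold lower number from compound 2 to compound 3 (0.15 log units; within the scatter) and the furthest is a 2.7-fold higher number from compound 1 to compound 3 (0.43 log units; beyond the scatter). Compound 4 `COc1cc(Cc2nc3c(N)ncnc3n2CC2(C)CC2)cc(OC)c1OC` has not yet been measured. The change is 1-methylcyclopropyl in place of methoxymethyl on a saturated chain carbon bound to an aromatic nitrogen. The measured steps that bear on it are a 2.7-fold higher number from compound 1 to compound 3 (0.43 log units; beyond the scatter) and a 1.4-fold lower number from compound 2 to compound 3 (0.15 log units; within the scatter): but-3-yn-1-yl in compound 1 gave the lowest number, and methoxymethyl in place of oxolan-2-yl changed little. A small downward step is therefore expected, a 1.7-fold lower number from compound 3 to compound 4 (0.23 log units; within the scatter). Compound 4 is estimated at 38000 nM, within 13000 nM to 110000 nM.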

Compound 4, half-maximal inhibitory concentration: 112000 nM
The estimate for compound 4 lay 2.9-fold (0.47 log units) below the measured number; measured number above the stated range.
By their numbers in this assay, from the lowest: compound 1; then compounds 3, 2 and 4 (each within the scatter of the next).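

In this assay the all-carbon 1-methylcyclopropyl gives a 1.7-fold higher number from compound 3 to compound 4 (0.24 log units; within the scatter) and a 1.2-fold higher number from compound 2 to compound 4 (0.09 log units; within the scatter) and so cannot be told apart from methoxymethyl or oxolan-2-yl, which means that having no hydrogen-bond acceptor in this group shows no change beyond the scatter. Going by these compounds alone, of the new steps, only the one from but-3-yn-1-yl stands beyond the scatter, as a 4.7-fold higher number from compound 1 to compound 4 (0.67 log units; beyond the scatter) shows. Nothing available explains this result.

Going by these compounds, whether the low number of compound 1 depends on its alkyne or on its chain length stays open. So does the effect of an amine or a carboxylic acid on this chain.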